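Phenylpiperazine amide series: fluoro added to compound 3

The compounds below may be only part of what the source reports. "The series", "measured", "known", "first", "only" and "open" are said of these compounds alone.

Among the compounds with values here, compound 3 (`CC(C)Cc1ccc(C(C)C(=O)N2CCN(c3ccccc3)CC2)cc1`) stands lowest of the three numbers measured so far: in an assay on brain for inhibition of Fatty-acid amide hydrolase 1 (Rattus norvegicus), read by scintillation counting, with a stated time of 10 min (a lower number here means a stronger inhibitor, a higher number a weaker inhibitor), compound 3 gives 4700 nM, and its gaps to both other compounds lie beyond the scatter, so it is the strongest inhibitor of the set. Compound 1 (`CC(C)Cc1ccc(C(C)C(=O)NCc2ccc(F)cc2)cc1`) gives 27000 nM in this assay, and compound 2 (`CC(C)Cc1ccc(C(C)C(=O)NCc2ccc(C(C)(C)C)cc2)cc1`) gives 25000 nM. Within the data shown here, the one single-point step among the measured compounds, a 1.1-fold lower number from compound 1 to compound 2 (0.03 log units; within the scatter), exchanges one substituent for another on an aromatic carbon and leaves the number essentially unchanged.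

Compound 4 (`CC(C)Cc1ccc(C(C)C(=O)N2CCN(c3ccc(F)cc3)CC2)cc1`) differs from compound 3 by fluoro in place of hydrogen on an aromatic carbon. Among the measured compounds shown here, no measured step in this assay puts fluoro in place of hydrogen, and the closest precedent, a 1.1-fold lower number from compound 1 to compound 2 (0.03 log units; within the scatter), sits on a different ring of the shared core and involves two non-hydrogen groups, so it bears on the present change only loosely. What it does show is that varying a substituent on an aromatic carbon, in that case, moved nothing beyond the scatter. The expected step is therefore small, a 1.2-fold lower number from compound 3 to compound 4 (0.07 log units; within the scatter), with no clear direction. Compound 4 is estimated to give 4000 nM in this assay, within a range of 1500 nM to 12000 nM.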

Compound 4, half-maximal inhibitory concentration: 17000 nM
Estimate against measurement, compound 4: 4.3-fold (0.63 log units) below; the whole stated range lies below it.
By their numbers in this assay, from the lowest: compound 3; then compounds 4, 2 and 1 (each within the scatter of the next).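

On the phenyl of compound 3, a fluoro para to a large group is not a silent change: the step is a 3.6-fold higher number from compound 3 to compound 4 (0.56 log units; beyond the scatter) in this assay, so this carbon responds even to a single fluorine atom. The earlier single-place step, a 1.1-fold lower number from compound 1 to compound 2 (0.03 log units; within the scatter), put tert-butyl in place of fluoro on a different ring and moved nothing beyond the scatter, so in these two pairs the two aromatic sites do not behave alike. The measurements at hand offer nothing that explains the rise in the number.

On these data alone, whether the rise belongs to fluoro itself or would follow any group on this carbon stays open, as a single substituent at a single place cannot separate the two; chloro, methoxy or an amine on the same carbon would bear on that question. Also open, as far as these compounds go, is whether fluoro on the other carbons of this ring gives a similar step, or whether this one is particular to the place para to the large group.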